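From iodo to methoxy on a shared core

The source may report more compounds than this note shows. Statements on the series, on what has been measured and on what is new or still open speak of the compounds shown alone.

- Compound 1 `COc1cc(/C=C/C(=O)c2ccc3ccccc3c2)cc(Br)c1OC`: 9300 nM
- Compound 2 `COc1cc(/C=C/C(=O)c2ccc3ccccc3c2)cc(I)c1OC`: 10400 nM
- Compound 3 `COc1cc(/C=C/C(=O)c2ccc3ccccc3c2)cc(OC)c1OC`: not yet measured

These values come from a functional assay on PANC-1 cells (Homo sapiens) for inhibition, read by MTT assay, with a stated time of 72 h; a lower number here means a stronger inhibitor, a higher number a weaker inhibitor. Compound 2 stands level with compound 1, their numbers lying within the scatter of each other. Compound 3 differs from compound 2 by one change, methoxy in place of iodo on an aromatic carbon. Going by the values given here, the one measured step, a 1.1-fold higher number from compound 1 to compound 2 (0.05 log units; within the scatter), is iodo in place of bromo and stays within the scatter. Among the compounds with values here, no measured compound shows methoxy at this place, so only a weak guide exists, and no step beyond the scatter is expected in this assay. The estimated change is a 1.2-fold higher number from compound 2 to compound 3 (0.06 log units; within the scatter). For compound 3 the expected value is 12000 nM, with an estimated range of 5000 nM to 30000 nM.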

Compound 3, half-maximal inhibitory concentration: 13300 nM
Compound 3: the middle estimate sits 1.1-fold (0.04 log units) below what was measured; the measured number falls inside the stated range.
By their numbers in this assay, from the lowest: compounds 1, 2 and 3 (each within the scatter of the next).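

In this assay, methoxy in place of iodo gives a 1.3-fold higher number from compound 2 to compound 3 (0.11 log units; within the scatter), and methoxy in place of bromo gives a 1.4-fold higher number from compound 1 to compound 3 (0.16 log units; within the scatter), so neither step leaves the scatter. The earlier compounds shown here had compared only two halogens at this place, ortho to a methoxy group; compound 3 shows that a group with a hydrogen-bond acceptor also produces no step beyond the scatter. No measurement here offers an explanation for these close numbers. Going by these compounds, whether an amine, a carboxylic acid or a longer alkoxy chain at this place would produce a step beyond the scatter remains open.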